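Dimethylsulfamoyl in place of formyl: compound 3

The source may hold more compounds than are shown below. What is called first, only, known or untested is meant among the compounds shown, and "the series" means these compounds.

Measured compounds, read in a physicochemical assay for lipophilicity, read by HPLC, measured as octanol-water partition (on this read-out higher numbers stand for higher lipophilicity and lower numbers for lower lipophilicity), as follows:
- compound 1 (`O=C(OC[C@H]1CN(c2ccc(-n3cc(-c4ccccn4)cn3)c(F)c2)C(=O)O1)c1ccccc1`) gives 4.21 on the scale
- compound 2 (`O=CNC[C@H]1CN(c2ccc(-n3cc(-c4ccccn4)cn3)c(F)c2)C(=O)O1`) gives 1.19 on the scale

Compound 2 stands lowest of the two numbers, well beyond the scatter from compound 1. Compound 3 (`CN(C)S(=O)(=O)NC[C@H]1CN(c2ccc(-n3cc(-c4ccccn4)cn3)c(F)c2)C(=O)O1`) is not yet measured. It differs from compound 2 as follows: dimethylsulfamoyl in place of formyl on an amine nitrogen. For the measured compounds named here, only one measured step bears on this, and only indirectly: a number 3.02 log units lower from compound 1 to compound 2 (beyond the scatter), a large step with formylamino in place of benzoyloxy. Going by the values given here, no measured step covers dimethylsulfamoyl itself. Among the compounds with values here, that large step shows only that changes on this chain can move this assay far. A moderate upward step is expected, estimated as a number 0.71 log units higher from compound 2 to compound 3 (beyond the scatter), much smaller than the measured one. For compound 3 the estimated value is 1.9, within an expected range from 1.3 to 2.5 on this scale.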

Compound 3, partition coefficient: 1.38
Compound 3: the middle estimate sits 0.52 log units above what was measured; measured number inside the range.
By their numbers in this assay, from the lowest: compounds 2 and 3 (each within the scatter of the next); then compound 1.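

In this assay the amine nitrogen takes dimethylsulfamoyl, with 6 heavy atoms, in place of formyl, with 2, and the step is a number 0.19 log units higher from compound 2 to compound 3 (within the scatter); at this position, the size of the group entering and its change from carbonyl to sulfonyl leave the read-out within the scatter. The large gap from the benzoyloxy compound is also not confined to formylamino, since (dimethylsulfamoyl)amino on the same chain carbon gives a number 2.83 log units lower from compound 1 to compound 3 (beyond the scatter). No measurement at hand bears on the reason for either step.

The compounds shown leave open whether the low numbers go with the amine nitrogen on the chain or with the particular groups carried on it. Benzoylamino on that chain carbon, set against the benzoyloxy of compound 1, or a free amine there, would separate these readings.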